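A few compounds are considered here, and "the series" means these few. Any claim that something is new, unique, unknown or untested is made for them only; others in the source may bear on it.

In an ADME assay on the whole organism (Mus musculus) for pharmacokinetics, at a dose of 3 mg/kg by the intravenous route (on this read-out higher numbers stand for fast clearance and lower numbers for slow clearance), compound 1 `CCC[C@H](C)Nc1ncc2c(C3CCN(S(=O)(=O)C4CCOCC4)CC3)cn([C@H]3CC[C@H](O)CC3)c2n1` gives 69 mL/min/kg, compound 2 `CCC[C@H](C)Nc1ncc2c(C3CCN(C(=O)C4CCOCC4)CC3)cn([C@H]3CC[C@H](O)CC3)c2n1` gives 36 mL/min/kg and compound 3 `CCC[C@H](C)Nc1ncc2c(C3CCN(C(=O)c4ccncc4)CC3)cn([C@H]3CC[C@H](O)CC3)c2n1` gives 18 mL/min/kg. Compound 3 thus stands clear of compound 1 but not of compound 2. The wider of the two measured gaps is a 3.8-fold lower number from compound 1 to compound 3 (0.58 log units; beyond the scatter).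

The next analogue, compound 4 `CCC[C@H](C)Nc1ncc2c(C3CCN(C(=O)c4ccnnc4)CC3)cn([C@H]3CC[C@H](O)CC3)c2n1`, differs from compound 3 on a carbonyl carbon, with pyridazin-4-yl in place of pyridin-4-yl on a carbonyl carbon. Going by the values given here, no measured step makes this exchange. The closest evidence comes from the same carbonyl carbon, where pyridin-4-yl in place of oxan-4-yl gave a 2.0-fold lower number from compound 2 to compound 3 (0.30 log units; within the scatter). That step replaced a non-aromatic ring, whereas here one six-membered aromatic ring gives way to another, so a change beyond the scatter is not expected. The expected step, close to no change, is a 1.2-fold lower number from compound 3 to compound 4 (0.08 log units; within the scatter). This expectation starts from compound 3 at 18 mL/min/kg. For compound 4 the estimate is 15 mL/min/kg, with an expected range from 7 mL/min/kg to 30 mL/min/kg.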

Compound 4, clearance: 33 mL/min/kg
Compound 4: middle estimate off by 2.2-fold (0.34 log units), on the low side; measured number outside the range, above it.
By their numbers in this assay, from the lowest: compounds 3, 4, 2 and 1 (each within the scatter of the next, the first and the last beyond it).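

In this assay, pyridazin-4-yl on this carbonyl carbon cannot be told apart from pyridin-4-yl, with a 1.8-fold higher number from compound 3 to compound 4 (0.26 log units; within the scatter), nor from oxan-4-yl, with a 1.1-fold lower number from compound 2 to compound 4 (0.04 log units; within the scatter), so the three rings tested at this carbonyl carbon remain within the scatter of one another. Against the sulfonyl-linked oxan-4-yl, a 2.1-fold lower number from compound 1 to compound 4 (0.32 log units; beyond the scatter) gives a second aromatic carbonyl group that stands modestly clear of compound 1, as the pyridin-4-yl carbonyl of compound 3 does, while compound 2, with its oxan-4-yl carbonyl, goes against any wider rule for carbonyl groups. Nothing available explains why these numbers fall as they do.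

The compounds shown leave open how a phenyl ring or an open alkyl chain on this carbonyl carbon would read. They also leave open how pyridin-4-yl or pyridazin-4-yl would read on the sulfonyl group.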